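This account rests on a few compounds, and the source may have more. Where it says the series, first, only, none or still open, it means among the compounds named here.

Measured so far:
compound 1 `O=C(COc1cccc2ccccc12)N/N=C/C=C/c1ccccc1` — 4.43
compound 2 `O=C(COc1cccc2ccccc12)N/N=C/c1ccccc1O` — 3.73

In a physicochemical assay for lipophilicity, measured as octanol-water partition (on this read-out higher numbers stand for higher lipophilicity and lower numbers for lower lipophilicity), compound 1 gives 4.43, and compound 2 gives 3.73. Going by the values given here, the only step known so far is a number 0.70 log units lower from compound 1 to compound 2 (beyond the scatter), 2-hydroxyphenyl in place of 2-phenylethenyl on a carbon with a double bond to nitrogen. Compound 2 therefore stands as the lowest of the two numbers, with compound 1 the nearest at a number beyond the scatter higher.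

Compound 3 `O=C(COc1cccc2ccccc12)N/N=C/c1ccccc1[N+](=O)[O-]` is not yet measured in this assay. It differs from compound 2 by nitro in place of hydroxy on an aromatic carbon. Among the compounds with values here, no measured step touches this exchange: the one known step swaps the whole aryl or alkenyl group on the imine carbon, not a single substituent on an otherwise unchanged ring, so it gives only a loose frame for the size of a substituent exchange on this core.

Within the data shown here, with no direct precedent, the expectation for compound 3 rests on the change alone; a small rise, at most near the edge of the scatter, is expected, a number 0.22 log units higher from compound 2 to compound 3 (within the scatter). For compound 3 this assay is expected to give 3.95, in the range 3.45 to 4.45.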

Compound 3, partition coefficient: 3.97
For compound 3 the middle estimate is 0.02 log units below the measured one; measured number inside the range.
By their numbers in this assay, from the lowest: compounds 2 and 3 (each within the scatter of the next); then compound 1.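

In this assay, going by these compounds alone, the first exchange of a single substituent on an otherwise unchanged ring reads a number 0.24 log units higher from compound 2 to compound 3 (within the scatter), so nitro in place of hydroxy, on an aromatic carbon ortho to a large group, does not separate the two compounds on this read-out. Within the data shown here, the two groups differ in heavy atoms and in hydrogen-bond donors and acceptors, yet that difference in the computed counts comes with no step beyond the scatter, and the only such step remains the exchange of the whole group on the carbon with a double bond to nitrogen, a number 0.70 log units lower from compound 1 to compound 2 (beyond the scatter). No measured evidence bears on why hydroxy and nitro read alike here.

The compounds shown leave open whether this position stays as flat for other kinds of substituent, such as an amine, a carboxylic acid or a longer alkyl chain, any of which could show whether a step beyond the scatter is reachable by changing one substituent alone. On these data alone, it also remains open whether nitro in place of hydroxy reads the same at another carbon of this ring.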